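Fluorine-to-hydroxyl swap on the benzylidene arm

The source may hold more compounds than are shown below. What is called first, only, known or untested is meant among the compounds shown, and "the series" means these compounds.

Three members of the series carry the same core and differ only in the aryl group on a double-bonded chain carbon bound to a double-bonded ring carbon. In a functional assay on NCI-H508 cells (Homo sapiens) for antiproliferative activity, read by MTT assay, with a stated time of 72 h (on this read-out lower numbers stand for stronger inhibition and higher numbers for weaker inhibition), compound 1 `COc1cc(/C=C2\CCC/C(=C\c3ccc(F)c(F)c3)C2=O)cc(OC)c1OC` gives 4000 nM, compound 2 `COc1cc(/C=C2\CCC/C(=C\c3ccc(O)c(O)c3)C2=O)cc(OC)c1OC` gives 7000 nM, and compound 3 `COc1cc(/C=C2\CCC/C(=C\c3ccccc3F)C2=O)cc(OC)c1OC` gives 2000 nM. Compound 3 thus shows the lowest number of the three; the step of a 2.0-fold lower number from compound 1 to compound 3 (0.30 log units; within the scatter) stays within the scatter, whereas a 3.5-fold lower number from compound 2 to compound 3 (0.54 log units; beyond the scatter) lies beyond it.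

Compound 4 `COc1cc(/C=C2\CCC/C(=C\c3cccc(O)c3)C2=O)cc(OC)c1OC` is obtained from compound 3 by the change (3-hydroxyphenyl in place of 2-fluorophenyl on a double-bonded chain carbon bound to a double-bonded ring carbon). For the measured compounds named here, two measured steps bear on this exchange of fluorine for hydroxyl on the aryl ring: a 1.8-fold higher number from compound 1 to compound 2 (0.24 log units; within the scatter), which is within the scatter, and the reverse of the step above, namely a 3.5-fold lower number from compound 2 to compound 3 (0.54 log units; beyond the scatter), which is beyond it. Going by the values given here, both point in the same direction, toward higher numbers when hydroxyl replaces fluorine, though compound 4 carries a single hydroxyl where compound 2 carried two, and the single substituent sits at a different site from the single fluorine of compound 3.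

A modest rise in this assay is therefore expected, a 2.0-fold higher number from compound 3 to compound 4 (0.30 log units; within the scatter). Compound 4 is estimated at 4000 nM, with a range from 1800 nM to 9000 nM.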

Compound 4, half-maximal inhibitory concentration: 5600 nM
Estimate against measurement, compound 4: 1.4-fold (0.15 log units) below; the range from low to high includes it.
By their numbers in this assay, from the lowest: compounds 3, 1, 4 and 2 (each within the scatter of the next, the first and the last beyond it).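

For the compounds shown here, the step from 2-fluorophenyl to 3-hydroxyphenyl on a double-bonded chain carbon bound to a double-bonded ring carbon gives a 2.8-fold higher number from compound 3 to compound 4 (0.45 log units; beyond the scatter) in this assay, the first direct reading of a hydroxyphenyl group against the best-placed member of the set, and it lies in the modest range. Going by these compounds alone, the new pair that differs only by hydrogen in place of hydroxy on an aromatic carbon gives a 1.3-fold lower number from compound 2 to compound 4 (0.10 log units; within the scatter), so removing that hydroxy from the aryl group leaves the number within the scatter, which the earlier compounds could not show. The step 3-hydroxyphenyl in place of 3,4-difluorophenyl gives a 1.4-fold higher number from compound 1 to compound 4 (0.15 log units; within the scatter), also within the scatter, so at this position only compound 3 stands apart from any other member, and only from compound 2 and compound 4.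

From the compounds shown here alone, the step to compound 4 alters the substituent and its place on the aryl ring at once, so the two contributions cannot be separated from these compounds, and whether an amine or a carboxylic acid on the same aryl ring would read like hydroxyl stays open. No measurement at hand accounts for any of these steps.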